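Cytotoxicity notes: from compound 2 to compound 3

A few compounds are considered here, and "the series" means these few. Any claim that something is new, unique, unknown or untested is made for them only; others in the source may bear on it.

Measured so far in an ADME assay on HEK293 cells (Homo sapiens) for cytotoxicity, read by CellTiter-Glo and resazurin assay, with a stated time of 72 h; on this read-out higher numbers stand for an effect only at larger amounts of compound and lower numbers for an effect already at smaller amounts
Compound 1 `CC(C)N(Cc1cccc(OCCCCCC(=O)O)c1)C(=O)c1ccc(-c2cccc(OCc3ccccc3)c2)cc1` gives > 26000 nM (a limit)
Compound 2 `COc1cc(F)cc(-c2ccc(C(=O)N(Cc3cccc(OCCCCCC(=O)O)c3)C(C)C)cc2)c1` gives > 26000 nM (a limit)

Compound 2 reports only the limit > 26000 nM and no number. Compound 1 likewise reports only the limit > 26000 nM and no number. The whole record so far is the limit of > 26000 nM in this assay, at which 2 of the 2 values shown sit, and nothing more. Compound 3 `CC(C)N(Cc1cccc(OCCCCCC(=O)O)c1)C(=O)c1ccc(-c2cccc(Cl)c2)cc1` carries 3-chlorophenyl in place of 3-fluoro-5-methoxyphenyl on an aromatic carbon, para to a large group (3-chlorophenyl in place of 3-fluoro-5-methoxyphenyl on an aromatic carbon). Among the measured compounds shown here, no step between measured compounds is available to size this change. The expectation rests on compound 2 with its limit > 26000 nM as the only anchor. The expected outcome is a number no higher from compound 2 to compound 3 (the limit leaves the size open) in this assay with no size beyond the scatter in either direction. For compound 3 the estimated value is 26000 nM with an expected range from 12000 nM to 40000 nM and a report as a limit is likely.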

Compound 3, half-maximal effective concentration: > 21900 nM
Compound 3: no number, only a limit; the forecaster's own chance of this, stated with the estimate: 80%; the middle value lies beyond the limit too.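

In this assay compound 3 gives only a limit, > 21900 nM. Among the compounds shown here, compound 1 and compound 2 are also recorded only as limits, so no step to compound 3 can be read from either. The compounds shown leave open where the half-maximal effective concentration of any of the three lies.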